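Swapping the Amide Ring on a Quinoline Growth Inhibitor

A few compounds are considered here, and "the series" means these few. Any claim that something is new, unique, unknown or untested is made for them only; others in the source may bear on it.

Of the compounds shown here, two built on one shared core have been tested so far. Compound 1 `COc1ncc(-c2ccc3nccc(/C(C)=C/C(=O)N(C)CCO)c3c2)cc1NS(=O)(=O)c1ccc(F)cc1F` gives 290 nM in a functional assay on PC-3 cells (Homo sapiens) for inhibition, read by sulforhodamine B assay, with a stated time of 72 h; on this read-out higher numbers stand for weaker inhibition of growth and lower numbers for stronger inhibition of growth. Compound 2 `COc1ncc(-c2ccc3nccc(/C=C/C(=O)N4CCN(C)CC4)c3c2)cc1NS(=O)(=O)c1ccc(F)cc1F` gives 450 nM in this assay. These two differ in one place, and the change from compound 1 to compound 2 moves the number by a 1.6-fold higher number from compound 1 to compound 2 (0.19 log units; within the scatter). Going by the values given here, on the two numbers at hand, compound 2 carries the higher one, with compound 1 the only neighbour and within the scatter of it.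

Compound 3 `COc1ncc(-c2ccc3nccc(/C(C)=C/C(=O)N4CCOCC4)c3c2)cc1NS(=O)(=O)c1ccc(F)cc1F` has not yet been measured. It differs from compound 2 as follows: 1-methyl-2-((morpholin-4-yl)carbonyl)ethenyl in place of 2-((4-methylpiperazin-1-yl)carbonyl)ethenyl on an aromatic carbon. Among the compounds with values here, the only measured step that bears on this change is the one from compound 1 to compound 2, which stayed within the scatter. Compound 3 is therefore expected to show a change from compound 2 of a 1.3-fold lower number from compound 2 to compound 3 (0.11 log units; within the scatter), that is, none beyond the scatter. Compound 3 is thus estimated at 350 nM, in a range from 150 nM to 900 nM.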

Compound 3, concentration for 50% growth inhibition: 1670 nM
Compound 3: the middle estimate sits 4.8-fold (0.68 log units) below what was measured; the whole stated range lies below it.
By their numbers in this assay, from the lowest: compounds 1 and 2 (each within the scatter of the next); then compound 3.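

Compound 3 shows that the group on the amide carbonyl can matter at this position. Going by these compounds alone, with the 1-methyl ethenyl link held fixed, morpholin-4-yl in place of (2-hydroxyethyl)(methyl)amino gives a 5.8-fold higher number from compound 1 to compound 3 (0.76 log units; beyond the scatter) in this assay, whereas the only earlier step stayed within the scatter. Replacing the 2-((4-methylpiperazin-1-yl)carbonyl)ethenyl group with the 1-methyl-2-((morpholin-4-yl)carbonyl)ethenyl group also weakens growth inhibition, with a 3.7-fold higher number from compound 2 to compound 3 (0.57 log units; beyond the scatter), but this step changes the ring and adds the methyl together, so it cannot show what each change contributes.

Still open, as far as these compounds go, are the separate effects of that methyl and that ring, and how a dimethylamino group on the same carbonyl carbon would read. Nothing at hand accounts for these shifts.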